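Fluoro for methyl on the aryl ring, electroshock series

This account rests on a few compounds, and the source may have more. Where it says the series, first, only, none or still open, it means among the compounds named here.

Compound 1 `COC(=O)NC1=NC(c2cccc(C)c2)CN1` gives 100 mg/kg in a functional assay on the whole organism for antagonist activity, with Mus musculus as the target, in the maximal electroshock model; a higher number here means that more compound is needed for the effect, a lower number that less compound is needed. Compound 2 `COC(=O)NC1=NC(c2cccc(F)c2)CN1` gives 70 mg/kg in this assay. The change between these two, (fluoro in place of methyl on an aromatic carbon), made a step of a 1.4-fold lower number from compound 1 to compound 2 (0.15 log units; within the scatter). Compound 3 `COC(=O)NC1=NC(c2ccccc2C)CN1C` gives 68 mg/kg in this assay; the difference between the core of compound 1 and the core of compound 3 is not broken down here. Compound 4 `COC(=O)NC1=NC(c2ccccc2F)CN1C` has not been measured in this assay. It differs from compound 3 by fluoro in place of methyl on an aromatic carbon, the same kind of change as that from compound 1 to compound 2, though there the place was meta to a large group and here it is ortho to a large group. A step of a 1.2-fold lower number from compound 3 to compound 4 (0.09 log units; within the scatter) is expected, resting on a 1.4-fold lower number from compound 1 to compound 2 (0.15 log units; within the scatter). Compound 4 is thus estimated at 55 mg/kg, most likely between 30 mg/kg and 110 mg/kg.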

Compound 4, dose for half-maximal effect: 74 mg/kg
For compound 4 the middle estimate is 1.3-fold (0.13 log units) below the measured one; low and high end bracket the measured number.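

In this assay, fluoro in place of methyl on the aromatic carbon gives a 1.1-fold higher number from compound 3 to compound 4 (0.04 log units; within the scatter). Set beside the earlier step, the two cores do not separate: the same change on two cores in this assay, a 1.4-fold lower number (0.15 log units; within the scatter) from compound 1 to compound 2 and a 1.1-fold higher number (0.04 log units; within the scatter) from compound 3 to compound 4, 1.6-fold (0.19 log units) apart, within the scatter of two such steps. This shows no detectable dependence of the change on the core, but with both steps within the scatter it does not show that the change has any effect on either core, and two small steps cannot exclude a real influence of the core or of the place.

Open, as far as these compounds go, is whether an amine or a trifluoromethyl on this aromatic carbon would give a step beyond the scatter on either core. From the compounds shown here alone, a longer chain in place of the methyl is equally open.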